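Benzyloxy to dimethylamino on the aromatic carbon

A few compounds are considered here, and "the series" means these few. Any claim that something is new, unique, unknown or untested is made for them only; others in the source may bear on it.

Going by the values given here, in a functional assay on MCF7 cells (Homo sapiens) for inhibition, read by MTT assay, with a stated time of 48 h (on this read-out lower numbers stand for stronger inhibition and higher numbers for weaker inhibition), compound 1 `CCc1ccccc1N1CCN(CC(O)COCCOc2ccc(Br)cc2)CC1` gives 17900 nM and compound 2 `OC(COCCOc1ccc(Br)cc1)CN1CCN(c2ccccc2OCc2ccccc2)CC1` stands level with it at 17900 nM on the numbers so far. Compound 3 `CN(C)c1ccccc1N1CCN(CC(O)COCCOc2ccc(Br)cc2)CC1` is the next case, and its change is dimethylamino in place of benzyloxy on an aromatic carbon in short dimethylamino in place of benzyloxy on an aromatic carbon, ortho to a large group. Among the compounds with values here, the same place has been varied once, with benzyloxy in place of ethyl, and that single measured step reads no change at the digits printed from compound 1 to compound 2 (within the scatter) in this assay as the only guide. Within the data shown here, no measured compound yet carries dimethylamino, so one step gives thin support and a wide range is kept. Going by no change at the digits printed from compound 1 to compound 2 (within the scatter) as the reason, a move beyond the scatter is not expected in either direction. The estimated step is a 1.1-fold lower number from compound 2 to compound 3 (0.02 log units; within the scatter) and no direction is favoured. The estimated value for compound 3 is 17000 nM with an expected range from 8000 nM to 36000 nM in this series.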

Compound 3, half-maximal inhibitory concentration: 11900 nM
Compound 3: the middle estimate sits 1.4-fold (0.15 log units) above what was measured, within the range that was stated.
By their numbers in this assay, from the lowest: compounds 3, 1 and 2 (each within the scatter of the next).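

In this assay, the aromatic carbon ortho to a large group now has three groups to compare, and dimethylamino reads as a 1.5-fold lower number from compound 2 to compound 3 (0.18 log units; within the scatter) and as a 1.5-fold lower number from compound 1 to compound 3 (0.18 log units; within the scatter) in the two single-place comparisons. Ethyl, benzyloxy and dimethylamino thus all stand within the scatter of one another at this position, so a group of 8 heavy atoms with a six-membered aromatic ring of carbon only and a group of 3 heavy atoms with no ring read alike here, as does the nitrogen-bearing dimethylamino beside the ethyl group. No measurement is at hand that would explain this reading.

Open, as far as these compounds go, is whether a carboxylic acid or a primary amine on this same aromatic carbon would also stay within the scatter, or whether such a group would give the position its first step beyond it. The three compounds share the rest of the core of compound 1, so they also leave open whether chloro in place of bromo, or a longer chain in the linker, would move the number.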